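The source may hold more compounds than are shown below. What is called first, only, known or untested is meant among the compounds shown, and "the series" means these compounds.

Compound 1 `N#C/N=C1\N(CCCCCOc2ccc(Cl)cc2)C(=O)CN1c1ccncc1` and compound 2 `N#C/N=C1\N(CCCCCCOc2ccc(Cl)cc2)C(=O)CN1c1ccncc1` have been measured in a functional assay on HepG2 cells (Homo sapiens) for cytotoxicity; a higher number here means a weaker inhibitor, a lower number a stronger inhibitor. Compound 1 gives 4200 nM, and compound 2 gives 392 nM. For the measured compounds named here, compound 2 therefore stands at the lowest of the two numbers, with compound 1 as its only neighbour.

Compound 3 `N#C/N=C1\N(CCCCCCCOc2ccc(Cl)cc2)C(=O)CN1c1ccncc1` has not yet been measured in this assay. It differs from compound 2 by (4-chlorophenoxy)methyl in place of 4-chlorophenoxy on a saturated chain carbon, six bonds along the chain from an amide-type nitrogen in a ring. Going by the values given here, the one measured step of the same kind is an 11-fold lower number from compound 1 to compound 2 (1.03 log units; beyond the scatter), a large drop, and nothing else bears on the change. On that single step alone, compound 3 is expected to give a somewhat lower number again, though with less confidence than one step can justify. Compound 3 is estimated at 200 nM, within a range of 60 nM to 800 nM. Compound 3 is thus expected to show a 2.0-fold lower number from compound 2 to compound 3 (0.29 log units; within the scatter).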

Compound 3, half-maximal inhibitory concentration: 2740 nM
For compound 3 the middle estimate is 14-fold (1.14 log units) below the measured one, and the stated range ends below it.
By their numbers in this assay, from the lowest: compound 2; then compounds 3 and 1 (each within the scatter of the next).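

In this assay the same change that gave an 11-fold lower number from compound 1 to compound 2 (1.03 log units; beyond the scatter) now reverses direction, giving a 7.0-fold higher number from compound 2 to compound 3 (0.84 log units; beyond the scatter), so its effect depends on the chain that carries it. Compound 2 therefore stands apart as the lowest of the three, while the remaining step, a 1.5-fold lower number from compound 1 to compound 3 (0.19 log units; within the scatter), lies within the scatter. Nothing available explains this reversal. On these data alone, what a longer chain would do remains open, as does whether the number seen for compound 2 would survive an amine or a carboxylic acid in place of the 4-chlorophenoxy group.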